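The compounds below may be only part of what the source reports. "The series", "measured", "known", "first", "only" and "open" are said of these compounds alone.

Compound 2, `COc1ccc(C2=NN(c3ccc(-c4ccccc4)nn3)C(c3ccc(Cl)cc3)C2)cc1`, was tested in a functional assay on Caco-2 cells (Homo sapiens) for antiproliferative activity, read by MTT assay, with a stated time of 24 h; a higher number here means a weaker inhibitor, a lower number a stronger inhibitor. In this assay compound 2 gives > 100000 nM, which is a limit of the assay rather than a measured number. Compound 1, `Fc1ccc(C2CC(c3ccc(Cl)cc3)=NN2c2ccc(-c3ccccc3)nn2)cc1`, was tested in the same way. In this assay compound 1 gives > 100000 nM, again a limit and not a number. Both results sit at the limit of > 100000 nM in this assay, at which 2 of the 2 values shown sit. For the measured compounds named here, compound 1 and compound 2 differ in more than one place, so no single step between them can be described; their two values show only that neither reached a measurable number.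

Compound 3, `COc1ccc(C2=NN(c3ccc(-c4ccccc4)nn3)C(c3ccc(F)cc3)C2)cc1`, has not yet been tested in this assay. It differs from compound 2 in one place: fluoro in place of chloro on an aromatic carbon. Going by the values given here, no measured step is available to show what such a change does here. With compound 2 sitting at the limit, the step in this assay is expected to be a step that the limit leaves unreadable from compound 2 to compound 3, no clear shift beyond the usual scatter. Compound 3 is therefore estimated at 150000 nM, within a range from 50000 nM to 500000 nM, and most likely the assay will again report only a limit.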

Compound 3, half-maximal inhibitory concentration: 18100 nM
Estimate against measurement, compound 3: 8.3-fold (0.92 log units) above, outside the stated range (below it).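

For the compounds shown here, the first measurable number shows that the 4-chlorophenyl position is not indifferent to what it carries: in this assay, the change from 4-chlorophenyl to 4-fluorophenyl gives an at least 5.5-fold lower number from compound 2 to compound 3 (0.74 log units; beyond the scatter), and a lower number here means a stronger inhibitor. The second listed step concerns a different place, where methoxy takes the place of chloro on an aromatic carbon and gives an at least 5.5-fold lower number from compound 1 to compound 3 (0.74 log units; beyond the scatter), so among these three compounds, the only one without a chloro group, compound 3, is also the only one to reach a measured value. The true size of either step cannot be fixed because each starts from a compound that gives only a limit, not a number: the limit of > 100000 nM in this assay, at which 2 of the 3 values shown sit.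

The compounds shown leave open whether the fluoro group itself matters or whether simply losing the chloro group would be enough, which a plain hydrogen, an amine or a carboxylic acid at the same place could help to settle. They also leave open how the two places on the core work together, since a single pair of groups yields a number.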